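The compounds below may be only part of what the source reports. "The series", "measured", "known", "first", "only" and "open" are said of these compounds alone.

Measured so far:
- compound 1, `CCC(C)(C)Cc1c[nH]c(CCc2ccc(-c3ccncc3)cc2)n1`: 305 nM
- compound 2, `CCC(C)(C)Cc1c[nH]c(CCc2ccc(-c3cnsc3)cc2)n1`: 44 nM

Among the compounds with values here, of these two, compound 2 stands at the lower number in a functional assay on HEK293 cells for agonist activity at Bombesin receptor subtype-3 (Homo sapiens), read by luminescence and calcium flux, with a stated time of 10 min; a lower number here means that less compound is needed, a higher number that more compound is needed for the effect; its only neighbour is compound 1, and the step of a 6.9-fold lower number from compound 1 to compound 2 (0.84 log units; beyond the scatter) lies beyond the scatter. The next compound, compound 3 with the structure `CCC(C)(C)Cc1c[nH]c(CCc2ccc(-c3cccnc3C(=O)O)cc2)n1`, differs from compound 2 in one place: 2-carboxypyridin-3-yl in place of 1,2-thiazol-4-yl on an aromatic carbon. Within the data shown here, the only measured step that bears on this is a 6.9-fold lower number from compound 1 to compound 2 (0.84 log units; beyond the scatter), in which the pyridin-4-yl ring of compound 1 gave 305 nM against the 1,2-thiazol-4-yl ring of compound 2. Among the measured compounds shown here, compound 3 returns to a six-membered ring with one nitrogen, now carrying a carboxylic acid, and nothing among the measured compounds shows what the carboxylic acid does. For the measured compounds named here, on the one comparison available, the expectation for compound 3 in this assay is a higher number than for compound 2, by a step estimated at a 9.1-fold higher number from compound 2 to compound 3 (0.96 log units; beyond the scatter), with wide uncertainty. The estimate for compound 3 is therefore 400 nM, within a range from 80 nM to 2500 nM.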

Compound 3, half-maximal effective concentration: 1260 nM
Compound 3: middle estimate off by 3.2-fold (0.50 log units), on the low side, and the stated range covers the measured number.
By their numbers in this assay, from the lowest: compound 2; then compound 1; then compound 3.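

At this position, on an aromatic carbon of a six-membered aromatic ring of carbon only, para to a large group, the third ring shows that the choice of group can move the number further than the first comparison suggested: in this assay, 2-carboxypyridin-3-yl in place of 1,2-thiazol-4-yl gives a 29-fold higher number from compound 2 to compound 3 (1.46 log units; beyond the scatter), a large step. Six-membered rings with one ring nitrogen also do not form a single level in this assay, as 2-carboxypyridin-3-yl in place of pyridin-4-yl gives a 4.1-fold higher number from compound 1 to compound 3 (0.62 log units; beyond the scatter), which is beyond the scatter. No measurement offered here accounts for either step.

The step between the two six-membered rings combines a different attachment of the ring with the added carboxylic acid, so the share of each remains unresolved. A plain pyridin-3-yl ring would separate the two, and a methyl ester or a primary amide in place of the carboxylic acid would show whether the higher number is specific to the acid or extends to other groups at that place on the ring.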